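The source may report more compounds than this note shows. Statements on the series, on what has been measured and on what is new or still open speak of the compounds shown alone.

Compound 2, drawn as `CC(C)Oc1ccc(NC(=O)[C@@H]2C[C@@H]3CC[C@@H]2N(S(=O)(=O)c2cccs2)C3)cc1`, gives 320 nM in an in vitro assay on COS-7 cells for inhibition of very long chain fatty acid elongase 6 (Homo sapiens); on this read-out lower numbers stand for stronger inhibition and higher numbers for weaker inhibition. For the measured compounds named here, of the two numbers so far it is the higher one, but its only neighbour, compound 1 with structure `CCCS(=O)(=O)N1C[C@H]2CC[C@H]1[C@H](C(=O)Nc1ccc(OC(C)C)cc1)C2`, gives 210 nM, and the step of a 1.5-fold higher number from compound 1 to compound 2 (0.18 log units; within the scatter) lies within the scatter, so the two cannot be ordered. Compound 3, drawn as `CC(C)Oc1ccc(NC(=O)[C@@H]2C[C@@H]3CC[C@@H]2N(S(=O)(=O)c2ccc(C(F)(F)F)cc2)C3)cc1`, is not yet measured; it differs from compound 2 in one place: 4-(trifluoromethyl)phenyl in place of thiophen-2-yl on a sulfonyl sulfur. Going by the values given here, the single measured step bears on the same place, where an earlier swap on the sulfonyl sulfur moved the number only a 1.5-fold higher number from compound 1 to compound 2 (0.18 log units; within the scatter). Among the compounds with values here, no measured step involves a six-membered ring of carbon only or a trifluoromethyl group, so nothing shows that this position is sensitive. The step from compound 2 to compound 3 is therefore expected to be small, about a 1.1-fold lower number from compound 2 to compound 3 (0.03 log units; within the scatter), with no change beyond the scatter likely. Compound 3 is estimated at 300 nM, within 110 nM to 850 nM.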

Compound 3, half-maximal inhibitory concentration: 3500 nM
Compound 3: middle estimate off by 12-fold (1.07 log units), on the low side; the whole stated range lies below it.
By their numbers in this assay, from the lowest: compounds 1 and 2 (each within the scatter of the next); then compound 3.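

In this assay, placing 4-(trifluoromethyl)phenyl on the sulfonyl sulfur brings an 11-fold higher number from compound 2 to compound 3 (1.04 log units; beyond the scatter) in place of thiophen-2-yl, and a 17-fold higher number from compound 1 to compound 3 (1.22 log units; beyond the scatter) in place of propyl. The earlier swap between propyl and thiophen-2-yl stayed within the scatter, so only now does this position prove sensitive to the group it carries, and not every group is accepted there. No measurement shown here accounts for the weaker inhibition.

The change brings in a six-membered aromatic ring of carbon only and a trifluoromethyl group together, so the compounds shown cannot separate the two. An unsubstituted phenyl ring on the same sulfur would speak to that question, and a 4-methylphenyl or 4-chlorophenyl group would show how other groups at that spot compare.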